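Chloro on the furan amide of compound 2

This account rests on a few compounds, and the source may have more. Where it says the series, first, only, none or still open, it means among the compounds named here.

Among the measured compounds shown here, compound 2 `Cc1cc(N2C(=O)C3=C(CCCC3)C2=O)c(F)cc1NC(=O)c1ccco1` in a functional assay for positive allosteric modulation of metabotropic glutamate receptor 7 (Homo sapiens), read by calcium flux, in the presence of a further agent that is not named here (on this read-out higher numbers stand for an effect only at larger amounts of compound and lower numbers for an effect already at smaller amounts), gives 377 nM; of the two numbers so far it sits alongside compound 1 `Cc1cc(N2C(=O)C3=C(CCCC3)C2=O)c(F)cc1NC(=O)c1occc1C`, which in this assay gives 372 nM, the step of a 1.0-fold higher number from compound 1 to compound 2 (0.01 log units; within the scatter) being within the scatter. Compound 3 `Cc1cc(N2C(=O)C3=C(CCCC3)C2=O)c(F)cc1NC(=O)c1ccc(Cl)o1` differs from compound 2 by chloro in place of hydrogen on an aromatic carbon. For the measured compounds named here, no measured step touches this change; the only step known, a 1.0-fold higher number from compound 1 to compound 2 (0.01 log units; within the scatter), concerned a methyl-to-hydrogen exchange on the same ring and moved nothing beyond the scatter. The expected step of a 1.0-fold higher number from compound 2 to compound 3 (0.00 log units; within the scatter) for compound 3 is therefore none beyond the scatter. Compound 3 is estimated at 380 nM, within 150 nM to 1000 nM.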

Compound 3, half-maximal effective concentration: 400 nM
Compound 3: the middle estimate sits 1.1-fold (0.02 log units) below what was measured; the range from low to high includes it.
By their numbers in this assay, from the lowest: compounds 1, 2 and 3 (each within the scatter of the next).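

In this assay, the carbon next to the ring oxygen, two ring bonds from the ring atom that bears a large group, accepts chloro with no change in the number: a 1.1-fold higher number from compound 2 to compound 3 (0.03 log units; within the scatter). Exchanging 3-methylfuran-2-yl for 5-chlorofuran-2-yl gives a 1.1-fold higher number from compound 1 to compound 3 (0.03 log units; within the scatter), so the furan amide shows no change across these substituents so far. Nothing available explains this flat result.

Still open, from the compounds shown here alone, is whether an amine or a carboxylic acid at this position would move the number beyond the scatter.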